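A few compounds are considered here, and "the series" means these few. Any claim that something is new, unique, unknown or untested is made for them only; others in the source may bear on it.

Measured so far:
- compound 1, `COc1ccc(-n2nc(Sc3ccc(Cl)cc3)cc(CC[C@@H](C)NC(=O)[C@H]3CNCC[C@@H]3c3ccc(C)cc3)c2=O)cc1`, 4.7 nM
- compound 2, `COc1ccc(-n2nc(Sc3ccc(Cl)cc3)cc(CC[C@@H](C)NC(=O)[C@H]3CCNC[C@@H]3c3ccc(Cl)cc3Cl)c2=O)cc1`, 36 nM

Both compounds were tested in an assay on CHO cells for binding affinity to Melanocortin receptor 4 (Homo sapiens); on this read-out lower numbers stand for stronger inhibition and higher numbers for weaker inhibition. Compound 1 gives 4.7 nM and compound 2 gives 36 nM, so compound 2 stands at the higher of the two numbers, and the gap to compound 1 lies beyond the usual scatter of such measurements. For the measured compounds named here, the two compounds differ in more than one place, so no single step between them can be read off.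

Compound 3, `COc1ccc(-n2nc(Sc3ccc(Cl)cc3)cc(CC[C@@H](C)NC(=O)[C@H]3CCNC[C@@H]3c3ccccc3F)c2=O)cc1`, is not yet measured. It is made from compound 2 by one change: 2-fluorophenyl in place of 2,4-dichlorophenyl on a saturated ring carbon. Going by the values given here, no measured pair shows this same change, so any expectation rests on the whole picture rather than on a directly comparable step. The step in this assay from compound 2 to compound 3 is expected to be small, about a 1.1-fold higher number from compound 2 to compound 3 (0.05 log units; within the scatter), with a direction that cannot be called with confidence. For compound 3 the expected value in this assay is 40 nM, with a plausible range from 10 nM to 160 nM.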

Compound 3, half-maximal inhibitory concentration: 100 nM
Compound 3: the middle estimate sits 2.5-fold (0.40 log units) below what was measured; measured number inside the range.
By their numbers in this assay, from the lowest: compound 1; then compound 2; then compound 3.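

In this assay, for the compounds shown here, the change from 2,4-dichlorophenyl to 2-fluorophenyl on the saturated ring carbon gives a 2.8-fold higher number from compound 2 to compound 3 (0.44 log units; beyond the scatter) and is the first step in this set that can be read at a single place. It shows that this position on the ring responds to what the aromatic ring carries, even though both groups are six-membered carbon rings with no hydrogen-bond donors or acceptors and no net charge. No measurement shown explains the step.

With groups such as 2-chlorophenyl or unsubstituted phenyl, the loss of a chlorine could be separated from the exchange of the other chlorine for fluorine, so the compounds shown leave open which part of the change matters. Compound 1 differs from the others in more than one place, so steps involving it cannot be read.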